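From Benzyl to 4-Cyanobenzyl: What the Cells May Tolerate

This account rests on a few compounds, and the source may have more. Where it says the series, first, only, none or still open, it means among the compounds named here.

In an ADME assay on MT4 cells (Homo sapiens) for cytotoxicity, read by MTT assay, with a stated time of 5 days (a higher number here means that more compound is tolerated, a lower number that less compound is tolerated), compound 1 `Cc1cc(C#N)cc(C)c1Oc1nc(NC2CCCN(Cc3ccc(S(N)(=O)=O)cc3)C2)nc2ccsc12` gives 1170 nM while compound 2 `Cc1cc(C#N)cc(C)c1Oc1nc(NC2CCC(NCc3ccccc3)CC2)nc2ccsc12` gives 2970 nM on the same scale. Compound 2 therefore holds the higher of the two numbers, and the gap between them lies beyond the usual scatter. The two compounds differ in more than one place, so their gap is not a clean guide to any single change.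

Compound 3 `Cc1cc(C#N)cc(C)c1Oc1nc(NC2CCC(NCc3ccc(C#N)cc3)CC2)nc2ccsc12` has yet to be measured in this assay and departs from compound 2 at one place only. Benzyl becomes 4-cyanobenzyl, with cyano in place of hydrogen on an aromatic carbon, para to a large group (cyano in place of hydrogen on an aromatic carbon). Among the compounds with values here, no measured pair shows what this change does, so the expectation starts from compound 2 at 2970 nM and assumes no shift in either direction. The estimate for a 1.0-fold higher number from compound 2 to compound 3 (0.00 log units; within the scatter) is expected to stay within the scatter. Compound 3 is estimated at 3000 nM with an expected range of 1100 nM to 9000 nM in this measurement.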

Compound 3, half-maximal cytotoxic concentration: 5150 nM
Estimate against measurement, compound 3: 1.7-fold (0.23 log units) below; the measured number falls inside the stated range.
By their numbers in this assay, from the lowest: compound 1; then compounds 2 and 3 (each within the scatter of the next).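

In this assay, within the data shown here, the change is read directly for the first time: cyano in place of hydrogen on an aromatic carbon, para to a large group, gives a 1.7-fold higher number from compound 2 to compound 3 (0.24 log units; within the scatter) and so cannot be told apart from repeat measurements of a single compound. The earlier compounds shown here could not show this, as compound 1 and compound 2 differ in more than one place and their gap cannot be assigned to any single change; this one pair now shows that the benzyl group of compound 2 can carry cyano at this position without a step beyond the scatter. No accompanying measurement bears on this result, and it offers no explanation for the reading.

A single step at a single position leaves open whether a different group in the same place, such as fluorine, methoxy, an amine or a carboxylic acid, would also stay within the scatter. It also leaves open whether cyano would read the same way elsewhere on the ring, or on the benzyl group of compound 1, whose surroundings differ.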